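Swapping an Aryl Group and Watching Liver Clearance

The compounds below may be only part of what the source reports. "The series", "measured", "known", "first", "only" and "open" are said of these compounds alone.

Compound 1 `O=S(=O)(c1ccc(F)c(Cl)c1)c1cnc2cc(F)ccc2c1-c1cccc(Cl)c1` was tested in an ADME assay on microsomes from liver (Homo sapiens) for metabolic stability, tested at 2.5 uM (on this read-out higher numbers stand for fast clearance and lower numbers for slow clearance), where compound 1 gives 0.66 mL/min. Among the three measured compounds it sits in the middle: compound 2 `COc1ccc(-c2c(S(=O)(=O)c3cc(F)cc(F)c3)cnc3c(F)cccc23)cc1` gives 2.59 mL/min, a higher number, while compound 3 `O=S(=O)(c1ccc(F)cc1)c1cnc2cc(F)c(Cl)cc2c1-c1ccc(Cl)cc1` gives 0.01 mL/min, a much lower one. The next compound, compound 4 `COc1ccc(-c2c(S(=O)(=O)c3ccc(F)c(Cl)c3)cnc3cc(F)ccc23)cc1`, keeps the shared core of compound 1 and changes one group: 4-methoxyphenyl in place of 3-chlorophenyl on an aromatic carbon. Compound 2 carries the same 4-methoxyphenyl and gives 2.59 mL/min, so the expected step from compound 1 to compound 4 in this assay is an increase, a 2.3-fold higher number from compound 1 to compound 4 (0.36 log units; beyond the scatter), beyond the scatter. For compound 4 the estimated result is 1.5 mL/min, expected to fall between 0.6 mL/min and 3.5 mL/min.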

Compound 4, intrinsic clearance in a liver preparation (reported as CLH), per the amount of preparation that the assay uses: 1.08 mL/min
The estimate for compound 4 lay 1.4-fold (0.14 log units) above the measured number, within the range that was stated.
By their numbers in this assay, from the lowest: compound 3; then compounds 1 and 4 (each within the scatter of the next); then compound 2.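

Among these compounds, until now no two compounds differed in one place only. In this assay the step is a 1.6-fold higher number from compound 1 to compound 4 (0.21 log units; within the scatter), so with the rest of the molecule held fixed, 4-methoxyphenyl and 3-chlorophenyl on this aromatic carbon cannot be told apart. No measurement shown here bears on the reason for this result.

Still open, from the compounds shown here alone, is whether a group of a different kind on this carbon, such as an amine or a carboxylic acid, would give a number beyond the scatter. Going by these compounds, the same swap on a different sulfonyl aryl group also remains open.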